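Trifluoromethyl in Place of Nitro: Expected Cytotoxicity

This account rests on a few compounds, and the source may have more. Where it says the series, first, only, none or still open, it means among the compounds named here.

Measured so far:
compound 1, `O=C(COC(=O)c1ccc([N+](=O)[O-])o1)NCC1CCCO1`: > 100000 nM
compound 2, `CC(C)(C)N(Cc1ccc([N+](=O)[O-])cc1)C(=O)COC(=O)c1ccc([N+](=O)[O-])o1`: > 100000 nM

In an ADME assay on MT4 cells (Homo sapiens) for cytotoxicity, read by MTT assay, with a stated time of 3 days (a higher number here means that more compound is tolerated, a lower number that less compound is tolerated), compound 1 gives > 100000 nM, which is a limit of the assay rather than a number. Compound 2 likewise gives > 100000 nM, again a limit. Compound 2 therefore stands at the limit of > 100000 nM in this assay, at which 2 of the 2 values shown sit. Compound 3, `CC(C)(C)N(Cc1ccc(C(F)(F)F)cc1)C(=O)COC(=O)c1ccc([N+](=O)[O-])o1`, differs from compound 2 by trifluoromethyl in place of nitro on an aromatic carbon. Among the compounds with values here, no step between measured compounds is available here. The step of a number no higher from compound 2 to compound 3 (the limit leaves the size open) is expected to be none beyond the scatter. Compound 3 is expected to give about 100000 nM, with a range from 50000 nM to 200000 nM, most likely reported again as a limit.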

Compound 3, half-maximal cytotoxic concentration: 71000 nM
Beside the measured number, compound 3's estimate is 1.4-fold (0.15 log units) above it, and the stated range covers the measured number.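

With trifluoromethyl at this position, compound 3 gives a measured number in this assay, 71000 nM. Compound 1 and compound 2 gave only limits. Trifluoromethyl in place of nitro on the six-membered aromatic ring therefore gives an at least 1.4-fold lower number from compound 2 to compound 3 (0.14 log units; that floor lies within the scatter). This is the first sign that a change at this position can bring the read-out within the measurable range, and most values shown remain limits: the limit of > 100000 nM in this assay, at which 2 of the 3 values shown sit.

From the compounds shown here alone, the true size of the step stays open, as compound 2 has only a limit. Going by these compounds, how an amine or a carboxylic acid at this position would read in this assay also remains unknown.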